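A fluoro-to-chloro swap carried to a larger analogue

A few compounds are considered here, and "the series" means these few. Any claim that something is new, unique, unknown or untested is made for them only; others in the source may bear on it.

Compound 1 `O=C(CSc1nc(Nc2ccccc2)c2ccccc2n1)Nc1ccccc1F` and compound 2 `O=C(CSc1nc(Nc2ccccc2)c2ccccc2n1)Nc1ccccc1Cl` share one core and differ in a single substituent. In a functional assay on PC-3 cells (Homo sapiens) for inhibition, read by MTT assay, with a stated time of 72 h (a lower number here means a stronger inhibitor, a higher number a weaker inhibitor), compound 1 gives 12400 nM, and compound 2 gives 14600 nM. The change between them, (chloro in place of fluoro on an aromatic carbon), made a step of a 1.2-fold higher number from compound 1 to compound 2 (0.07 log units; within the scatter). Compound 3 `C=CC(=O)Nc1cccc(NC(=O)CSc2nc(Nc3ccccc3F)c3ccccc3n2)c1` carries a larger outer part than compound 1; the difference between the two cores is not broken down here. In this assay compound 3 gives 9340 nM, and this value lies within the scatter of those of compound 1 and compound 2. Compound 4 `C=CC(=O)Nc1cccc(NC(=O)CSc2nc(Nc3ccccc3Cl)c3ccccc3n2)c1` has not yet been measured. It differs from compound 3 by chloro in place of fluoro on an aromatic carbon, the same change as that between compound 1 and compound 2, at the same place. Because the step of a 1.2-fold higher number from compound 1 to compound 2 (0.07 log units; within the scatter) lay within the scatter, compound 4 is expected to show a similarly small step, a 1.2-fold higher number from compound 3 to compound 4 (0.07 log units; within the scatter). In this assay compound 4 is therefore estimated at 11000 nM, with a likely range from 5000 nM to 25000 nM.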

Compound 4, half-maximal inhibitory concentration: 14400 nM
For compound 4 the middle estimate is 1.3-fold (0.12 log units) below the measured one; measured number inside the range.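

In this assay, chloro in place of fluoro gave a 1.5-fold higher number from compound 3 to compound 4 (0.19 log units; within the scatter), so on the larger core, as on the smaller one, the step stays within the scatter. Set side by side, the two steps cannot be told apart, and the change looks the same on both cores as far as this read-out can tell: the same change on two cores in this assay, a 1.2-fold higher number (0.07 log units; within the scatter) from compound 1 to compound 2 and a 1.5-fold higher number (0.19 log units; within the scatter) from compound 3 to compound 4, 1.3-fold (0.12 log units) apart, within the scatter of two such steps. Among these compounds, this rests on only two pairs of compounds, and it does not show that fluoro and chloro are truly interchangeable here, or that the match would hold on a third core.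

The compounds shown leave open how other groups would behave in the same place, such as a bromo, a methyl, a methoxy or an amine in place of the fluoro or chloro. From the compounds shown here alone, compound 1 and compound 3 differ in more than one place, so what each part of that larger difference contributes also stays open.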